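The source may hold more compounds than are shown below. What is called first, only, known or untested is meant among the compounds shown, and "the series" means these compounds.

Measured in an ADME assay on MDCKII-LE cells (Canis lupus familiaris) for permeability; on this read-out lower numbers stand for lower permeability and higher numbers for higher permeability:
Compound 1 `Cc1ccc(NC(=O)[C@H](CC2CCCC2)n2cnc(C(F)(F)F)c2)nc1`: 17.4 10^-6 cm/s
Compound 2 `O=C(O)c1ccc(NC(=O)[C@H](CC2CCCC2)n2cnc(C(F)(F)F)c2)nc1`: 1 10^-6 cm/s
Compound 3 `O=C(O)Cc1ccc(NC(=O)[C@H](CC2CCCC2)n2cnc(C(F)(F)F)c2)nc1`: 0.4 10^-6 cm/s

Compound 3 stands lowest of the three, at 0.4 10^-6 cm/s, clearly under both other compounds. Compound 4 `O=C(Nc1ccc(S(=O)(=O)O)cn1)[C@H](CC1CCCC1)n1cnc(C(F)(F)F)c1` has sulfo in place of carboxymethyl on an aromatic carbon of a six-membered aromatic ring with 1 nitrogen: sulfo in place of carboxymethyl on an aromatic carbon. Going by the values given here, no measured step involves sulfo, so the evidence is indirect. Carboxy in place of methyl gave a 17-fold lower number from compound 1 to compound 2 (1.24 log units; beyond the scatter), and carboxy in place of hydrogen on the saturated chain carbon gave a 44-fold lower number from compound 1 to compound 3 (1.64 log units; beyond the scatter). Both are large, but both start from compound 1, at the top of the range. The closest comparison is carboxymethyl in place of carboxy on the aromatic carbon, which gave only a modest 2.5-fold lower number from compound 2 to compound 3 (0.40 log units; beyond the scatter). In this assay, a further large fall is therefore not expected, and any expected move is slightly downward and within the scatter. The estimate amounts to a 1.3-fold lower number from compound 3 to compound 4 (0.12 log units; within the scatter). For compound 4 the expected value is 0.3 10^-6 cm/s, with an estimated range from 0.1 10^-6 cm/s to 0.8 10^-6 cm/s.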

Compound 4, apparent permeability: 0.7 10^-6 cm/s
Beside the measured number, compound 4's estimate is 2.3-fold (0.37 log units) below it; measured number inside the range.
By their numbers in this assay, from the lowest: compounds 3, 4 and 2 (each within the scatter of the next, the first and the last beyond it); then compound 1.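

In this assay sulfo on this aromatic carbon, two atoms from the ring nitrogen and para to a large group, cannot be told apart from the two groups it was compared with: the change reads as a 1.8-fold higher number from compound 3 to compound 4 (0.24 log units; within the scatter) against carboxymethyl and as a 1.4-fold lower number from compound 2 to compound 4 (0.15 log units; within the scatter) against carboxy. Against methyl it reads as a 25-fold lower number from compound 1 to compound 4 (1.40 log units; beyond the scatter), so the large gap seen earlier for carboxy and carboxymethyl also holds for a third group, with sulfo grouped alongside them and compound 1 alone at the top. Nothing measured here explains this grouping.

As far as these compounds go, whether an amine or a methyl sulfone on the same aromatic carbon would stay near compound 1 or join compounds 2, 3 and 4 remains open. So does whether a longer chain ending in carboxy or sulfo would keep the number this low.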